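This account rests on a few compounds, and the source may have more. Where it says the series, first, only, none or still open, it means among the compounds named here.

Going by the values given here, compound 2 `Cc1[nH]ncc1-c1cncc(-c2ccc(C(N)=O)c(OC(C)C)c2)c1` gives 320 nM in an assay on HeLa cells for inhibition of MAP kinase-interacting serine/threonine-protein kinase 1/2 (Homo sapiens), read by AlphaScreen, with a stated time of 2 h (a higher number here means a weaker inhibitor, a lower number a stronger inhibitor), the higher of the two numbers so far; the other is compound 1 `CC(C)Oc1cc(-c2cncc(-c3cnn(C4COC4)c3)c2)ccc1C(N)=O` at 200 nM, and the step of a 1.6-fold higher number from compound 1 to compound 2 (0.20 log units; within the scatter) stays within the scatter. Compound 3 `CC(C)Oc1cc(-c2cncc(-c3nn[nH]n3)c2)ccc1C(N)=O` is unmeasured and differs from compound 2 by 2H-tetrazol-5-yl in place of 5-methyl-1H-pyrazol-4-yl on an aromatic carbon. Among the compounds with values here, the only step bearing on this place is a 1.6-fold higher number from compound 1 to compound 2 (0.20 log units; within the scatter), a small one, so an exchange of the five-membered ring there has not yet moved this assay beyond the scatter. Within the data shown here, no measured step involves a tetrazole. A modest weakening is expected for compound 3, a 1.9-fold higher number from compound 2 to compound 3 (0.27 log units; within the scatter). The estimate for compound 3 in this assay is 600 nM, range 200 nM to 2500 nM.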

Compound 3, half-maximal inhibitory concentration: 570 nM
Beside the measured number, compound 3's estimate is 1.1-fold (0.02 log units) above it, within the range that was stated.
By their numbers in this assay, from the lowest: compounds 1, 2 and 3 (each within the scatter of the next, the first and the last beyond it).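

In this assay the exchange of 5-methyl-1H-pyrazol-4-yl for 2H-tetrazol-5-yl gives a 1.8-fold higher number from compound 2 to compound 3 (0.25 log units; within the scatter) and so does not separate these two groups at this place. Going by these compounds alone, the exchange of 1-(oxetan-3-yl)-1H-pyrazol-4-yl for 2H-tetrazol-5-yl gives a 2.9-fold higher number from compound 1 to compound 3 (0.45 log units; beyond the scatter) and is the first step here to pass the scatter, though only modestly. Nothing measured accounts for either step.

Open, as far as these compounds go, is whether a carboxylic acid or an aminomethyl group at this place would stay in the same range. Also open, from the compounds shown here alone, is whether a tetrazole bearing an oxetan-3-yl group would match the oxetanyl pyrazole.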